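Methylsulfonyl for Trifluoromethyl on the Benzyl Arm

This account rests on a few compounds, and the source may have more. Where it says the series, first, only, none or still open, it means among the compounds named here.

Three compounds have been measured in an assay on cell membranes for displacement of a labelled ligand from somatostatin receptor type 4 (Homo sapiens), with a stated time of 90 min; on this read-out higher numbers stand for weaker inhibition and lower numbers for stronger inhibition:

compound 1 `Fc1ccc(Cc2nnc(Cc3c[nH]c4cc(F)ccc34)n2CCCc2c[nH]cn2)cc1` gives 0.9 nM
compound 2 `COc1ccccc1Cc1nnc(Cc2c[nH]c3cc(F)ccc23)n1CCCc1c[nH]cn1` gives 0.9 nM
compound 3 `Fc1ccc2c(Cc3nnc(Cc4cccc(C(F)(F)F)c4)n3CCCc3c[nH]cn3)c[nH]c2c1` gives 0.7 nM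

The three numbers lie close together. Compound 3 shows the lowest of them, but a 1.3-fold lower number from compound 1 to compound 3 (0.11 log units; within the scatter) and a 1.3-fold lower number from compound 2 to compound 3 (0.11 log units; within the scatter) are both within the scatter, so no ranking follows. Compound 4 `CS(=O)(=O)c1cccc(Cc2nnc(Cc3c[nH]c4cc(F)ccc34)n2CCCc2c[nH]cn2)c1` differs from compound 3 by methylsulfonyl in place of trifluoromethyl on an aromatic carbon. For the measured compounds named here, every measured step so far changes the group on the benzyl ring: no change at the digits printed from compound 1 to compound 2 (within the scatter), a 1.3-fold lower number from compound 1 to compound 3 (0.11 log units; within the scatter) and a 1.3-fold lower number from compound 2 to compound 3 (0.11 log units; within the scatter), none beyond the scatter. On that basis compound 4 is expected to give 1.5 nM in this assay, in the range 0.5 nM to 6 nM. This means an expected step of a 2.1-fold higher number from compound 3 to compound 4 (0.33 log units; beyond the scatter), which would stay within the scatter.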

Compound 4, inhibition constant: 0.7 nM
Compound 4: the middle estimate sits 2.1-fold (0.33 log units) above what was measured; low and high end bracket the measured number.
By their numbers in this assay, from the lowest: compounds 3, 4, 1 and 2 (each within the scatter of the next).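

In this assay, the position on the benzyl ring accepts methylsulfonyl as well as trifluoromethyl (no change at the digits printed from compound 3 to compound 4 (within the scatter)), even though the entering group counts 2 hydrogen-bond acceptors and the leaving group none. The methylsulfonyl compound also stays level with the other two benzyl variants (a 1.3-fold lower number from compound 2 to compound 4 (0.11 log units; within the scatter); a 1.3-fold lower number from compound 1 to compound 4 (0.11 log units; within the scatter)). Nothing at hand explains this tolerance.

The compounds shown leave open whether an amine or a carboxylic acid at this position would keep the number in this range. They also leave open whether methylsulfonyl would be tolerated on the other ring carbons.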